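The source may hold more compounds than are shown below. What is called first, only, known or untested is meant among the compounds shown, and "the series" means these compounds.

Measured in a functional assay on A549 cells (Homo sapiens) for antiproliferative activity, read by MTT assay, with a stated time of 72 h; a lower number here means a stronger inhibitor, a higher number a weaker inhibitor:

- compound 1 `O=C(N/N=C/c1ccc([N+](=O)[O-])cc1)Nc1ccc(Oc2ccnc3[nH]ccc23)c(F)c1`: 20 nM
- compound 2 `O=C(N/N=C/c1ccc(Cl)c(Cl)c1)Nc1ccc(Oc2ccnc3[nH]ccc23)c(F)c1`: 2650 nM

Of the two, compound 2 has the higher number, 2650 nM. Among the compounds with values here, the only measured step, a 130-fold higher number from compound 1 to compound 2 (2.12 log units; beyond the scatter), is large and lies beyond the scatter. It was made at the same place as the next change. Compound 3 `O=C(N/N=C/c1cc(Br)c(O)c(Br)c1)Nc1ccc(Oc2ccnc3[nH]ccc23)c(F)c1` keeps the shared core and differs from compound 2 in one group: 3,5-dibromo-4-hydroxyphenyl in place of 3,4-dichlorophenyl on a carbon with a double bond to nitrogen. This puts 3,5-dibromo-4-hydroxyphenyl in place of 3,4-dichlorophenyl on a carbon with a double bond to nitrogen. Within the data shown here, the measured step shows that numbers can move far at this place in this assay, but no measured compound carries the entering group, so the direction remains uncertain. A moderate move toward a lower number is expected, well short of that large step. The expected change is a 2.7-fold lower number from compound 2 to compound 3 (0.42 log units; beyond the scatter). For compound 3 the estimated value is 1000 nM, with an expected range from 150 nM to 5000 nM.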

Compound 3, half-maximal inhibitory concentration: 16200 nM
Compound 3: middle estimate off by 16-fold (1.21 log units), on the low side, and the stated range ends below it.
By their numbers in this assay, from the lowest: compound 1; then compound 2; then compound 3.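

In this assay, replacing 3,4-dichlorophenyl with 3,5-dibromo-4-hydroxyphenyl gives a 6.1-fold higher number from compound 2 to compound 3 (0.79 log units; beyond the scatter), a modest step showing that the number at this place can climb further even after the large rise seen earlier. Across the three compounds the span widens to an 810-fold higher number from compound 1 to compound 3 (2.91 log units; beyond the scatter), and compound 1, with its 4-nitrophenyl group, keeps the lowest number, with both of its steps beyond the scatter. Nothing available explains why these groups rank in this order.

Compound 3 brings in the hydroxyl and the two bromines together, so the step cannot be assigned to either of them alone. On these data alone, how an unsubstituted phenyl, or a phenyl carrying a nitrile or an amine, would stand at this place remains open.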